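The compounds below may be only part of what the source reports. "The series", "measured", "known", "first", "only" and "open" are said of these compounds alone.

In an ADME assay on NCI/ADR-RES cells (Homo sapiens) for inhibition, read by MTT assay, with a stated time of 48 h (a lower number here means a stronger inhibitor, a higher number a weaker inhibitor), compound 1 `CC(=O)O[C@@H]1C[C@@H](OC(=O)c2ccccc2)/C(C)=C/[C@H]2[C@@H](OC(=O)c3ccccc3)[C@@H](C)[C@H](O)[C@]2(OC(C)=O)[C@H](O)[C@](C)(O)/C=C/C1(C)C` gives > 150000 nM, which is a limit of the assay and not a number. Compound 2 `CC(=O)O[C@@H]1C[C@@H](OC(=O)c2ccccc2)/C(C)=C/[C@H]2[C@@H](OC(=O)c3ccccc3)[C@@H](C)[C@H](OS(=O)(=O)c3ccc(C)cc3)[C@]2(OC(C)=O)[C@H](O)[C@](C)(O)/C=C/C1(C)C` gives > 150000 nM, also a limit and not a number. Compound 2 therefore has no measured potency of its own, and the evidence so far amounts to the limit of > 150000 nM in this assay, at which 2 of the 2 values shown sit.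

The next structure, compound 3 `CC(=O)O[C@@H]1C[C@@H](OC(=O)c2ccccc2)/C(C)=C/[C@H]2[C@@H](OC(=O)c3ccccc3)[C@@H](C)[C@H](OC(=O)c3ccc(Br)cc3)[C@]2(OC(C)=O)[C@H](O)[C@](C)(O)/C=C/C1(C)C`, keeps the core of compound 2 and changes one group, with (4-bromophenyl)carbonyl in place of (4-methylphenyl)sulfonyl on an oxygen on a saturated carbon.

For the measured compounds named here, only one measured step bears on this change, since it involves the same oxygen. That step is a step that the two limits leave unreadable from compound 1 to compound 2, which came with placing (4-methylphenyl)sulfonyl there in place of hydrogen. It offers no size to carry forward, so no step beyond the scatter is expected in this assay, and another reading reported only as a limit would be no surprise.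

On that basis, the expected step is a number no higher from compound 2 to compound 3 (the limit leaves the size open).

Compound 3 is estimated at 150000 nM, with an expected range from 60000 nM to 300000 nM.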

Compound 3, half-maximal inhibitory concentration: > 150000 nM
Compound 3: a limit, no number (the forecaster's own chance of this, stated with the estimate: 70%); the middle value sits exactly at the limit.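

Compound 3, like compound 1 and compound 2, gives only a limit of the assay and not a number in this assay, so no step among these three compounds can be read. What the compounds shown leave open is how strongly any of them inhibits, and whether any group on this oxygen changes that: the limit of > 150000 nM in this assay, at which 3 of the 3 values shown sit.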